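Cyclopropyl to 1-isopropyl-1H-pyrazol-4-yl: working notes on the series

A few compounds are considered here, and "the series" means these few. Any claim that something is new, unique, unknown or untested is made for them only; others in the source may bear on it.

Going by the values given here, in an ADME assay (liver) for metabolic stability, with Liver microsome (Homo sapiens) as the target, using microsomes and NADPH, with a stated time of 30 min, tested at 1 uM (a lower number here means slower removal, a higher number faster removal of the compound), compound 2 (`Nc1ccc(S(=O)(=O)N2CCN(c3ncc(C(O)(C(F)(F)F)C(F)(F)F)cc3C3CC3)CC2)cn1`) gives 38 mL.min-1.g-1, the only true number in this small set. Compound 1 (`COc1cc(C(O)(C(F)(F)F)C(F)(F)F)cnc1N1CCN(S(=O)(=O)c2ccc(N)nc2)CC1`) reads < 14 mL.min-1.g-1, which is a limit of the assay. Compound 3 (`Nc1ccc(S(=O)(=O)N2CCN(c3ncc(C(O)(C(F)(F)F)C(F)(F)F)cc3C#CCCO)CC2)cn1`) reads < 14 mL.min-1.g-1, which is also a limit. Two measured steps set compound 2 apart: an at least 2.7-fold higher number from compound 1 to compound 2 (0.43 log units; beyond the scatter), and an at least 2.7-fold lower number from compound 2 to compound 3 (0.43 log units; beyond the scatter). The third, a step that the two limits leave unreadable from compound 1 to compound 3, adds nothing on size.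

Compound 4 (`CC(C)n1cc(-c2cc(C(O)(C(F)(F)F)C(F)(F)F)cnc2N2CCN(S(=O)(=O)c3ccc(N)nc3)CC2)cn1`) has 1-isopropyl-1H-pyrazol-4-yl in place of cyclopropyl on an aromatic carbon. The steps show that the group at this place can move the number in this assay, but none of them involves this group, so they give no direction for the change. The expectation therefore rests on compound 2 at 38 mL.min-1.g-1. The expected step, a 1.3-fold lower number from compound 2 to compound 4 (0.10 log units; within the scatter), stays within the scatter. Compound 4 is estimated at 30 mL.min-1.g-1, with an expected range of 14 mL.min-1.g-1 to 70 mL.min-1.g-1.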

Compound 4, intrinsic clearance in microsomes: 38 mL.min-1.g-1
Compound 4: middle estimate off by 1.3-fold (0.10 log units), on the low side; the measured number falls inside the stated range.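

In this assay, this position accepts 1-isopropyl-1H-pyrazol-4-yl in place of cyclopropyl with no change at the digits printed from compound 2 to compound 4 (within the scatter), so the entry of a five-membered aromatic ring with 2 hetero atoms and 2 hydrogen-bond acceptors leaves the reading where it was. The new group stands with cyclopropyl and apart from both 4-hydroxybut-1-yn-1-yl and methoxy, with an at least 2.7-fold higher number from compound 3 to compound 4 (0.43 log units; beyond the scatter) and an at least 2.7-fold higher number from compound 1 to compound 4 (0.43 log units; beyond the scatter). These last two steps give only a minimum size, and the full gap stays unread: the limit of < 14 mL.min-1.g-1 in this assay, at which 2 of the 4 values shown sit.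

Still open, on these data alone, is whether an amine or a carboxylic acid at this position would read with compound 2 and compound 4 or with compound 1 and compound 3. The compounds shown also do not tell whether a hydroxyl on the isopropyl group of compound 4 would shift its reading.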